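Methyl Added on the Five-Membered Ring of Two Cores

The compounds below may be only part of what the source reports. "The series", "measured", "known", "first", "only" and "open" are said of these compounds alone.

Measured in a functional assay on the whole organism (strain Wistar Albino) for inhibition, with Rattus norvegicus as the target, read by paw edema, with a stated time of 4 h, at a dose of 20 mg/kg; on this read-out lower numbers stand for less inhibition and higher numbers for more inhibition at the one dose given (going by the name of the read-out):
compound 1 `COc1ccc(Cl)c(-c2nnc3sc(Cc4c[nH]c5ccc(OC)cc45)nn23)c1`: 33.9%
compound 2 `COc1ccc2[nH]cc(Cc3nn4c(Cc5ccc(OC)c(OC)c5)nnc4s3)c2c1`: 29.6%
compound 3 `COc1ccc(Cl)c(-c2nnc3sc(Cc4c(C)[nH]c5ccc(OC)cc45)nn23)c1`: 32.7%

Compound 1 and compound 3 share a core and differ in one place, (methyl in place of hydrogen on an aromatic carbon). The step this change made was a number 1.2 percentage points lower from compound 1 to compound 3 (within the scatter). Compound 2 is built on a different core from compound 1; the difference between the two cores is not broken down here, and the two values are close to each other.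

Compound 4 `COc1ccc2[nH]c(C)c(Cc3nn4c(Cc5ccc(OC)c(OC)c5)nnc4s3)c2c1` has not yet been measured. It differs from compound 2 by methyl in place of hydrogen on an aromatic carbon, which is the same change as that from compound 1 to compound 3, at the same kind of place. Since the change occurs twice among these compounds, and its one measured instance is a number 1.2 percentage points lower from compound 1 to compound 3 (within the scatter), it is expected that compound 4 in this assay gives about 28.5%, estimated to fall between 20% and 37%. The expected step behind this is a number 1.1 percentage points lower from compound 2 to compound 4 (within the scatter), small and within the scatter.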

Compound 4, a percentage reported as inhibition, in the whole organism at one dose (the size of the read-out at that dose, not a potency): 28.4%
The estimate for compound 4 lay 0.1 percentage points above the measured number; low and high end bracket the measured number.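

In this assay, methyl in place of hydrogen on an aromatic carbon gave a number 1.2 percentage points lower from compound 2 to compound 4 (within the scatter), and the change reads alike on the two cores: the same change on two cores in this assay, a number 1.2 percentage points lower (within the scatter) from compound 1 to compound 3 and a number 1.2 percentage points lower (within the scatter) from compound 2 to compound 4, 0 percentage points apart, within the scatter of two such steps. In these two pairs, then, a methyl on this aromatic carbon left the read-out within the scatter on either core. This does not show that the methyl has a real effect of its own on inhibition, nor does it speak for any core beyond these two.

The compounds shown leave open whether another group on the same aromatic carbon, such as an amine, a carboxylic acid or a longer chain, would move the read-out beyond the scatter. They also leave open how the methyl would read at other doses or times.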